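Benzyl variation on a trimethoxyphenyl thioacetamide core

The compounds below may be only part of what the source reports. "The series", "measured", "known", "first", "only" and "open" are said of these compounds alone.

Compound 1 `COc1cc(N(Cc2ccc(F)cc2)C(=O)CSc2nc3ccccc3s2)cc(OC)c1OC`: 50800 nM
Compound 2 `COc1ccc(CN(C(=O)CSc2nc3cc(Br)ccc3s2)c2cc(OC)c(OC)c(OC)c2)cc1O`: 8210 nM
Compound 3 `COc1cc(CN(C(=O)CSc2nc3ccccc3s2)c2cc(OC)c(OC)c(OC)c2)cc(OC)c1OC`: > 80000 nM

In a functional assay on PC-3 cells (Homo sapiens) for antiproliferative activity, read by MTT assay, with a stated time of 48 h (a higher number here means a weaker inhibitor, a lower number a stronger inhibitor), compound 1 gives 50800 nM, the highest of the two numbers available. Compound 2 stands closest, with 8210 nM. Compound 3 gives only a limit, > 80000 nM; its result is the limit of > 80000 nM in this assay, at which 1 of the 3 values shown sits. The step of an at least 1.5-fold higher number from compound 1 to compound 3 (0.19 log units; that floor lies within the scatter) shows that replacing the 4-fluorophenyl changed little that can be resolved. Compound 4 `COc1ccc(CN(C(=O)CSc2nc3ccccc3s2)c2cc(OC)c(OC)c(OC)c2)cc1C(F)(F)F` is the next variation, with 4-methoxy-3-(trifluoromethyl)phenyl in place of 4-fluorophenyl on a saturated chain carbon bound to an amide-type nitrogen. Among the compounds with values here, no measured step carries the same change, so the account rests on compound 1 and on the unresolved step to compound 3. The expected step is a 1.3-fold lower number from compound 1 to compound 4 (0.10 log units; within the scatter), a modest one whose direction is uncertain. Compound 4 is therefore estimated at 40000 nM, within 10000 nM to 80000 nM.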

Compound 4, half-maximal inhibitory concentration: > 80000 nM
Compound 4: a limit, no number; the forecaster's own chance of this, stated with the estimate: 25%; at least 2.0-fold (0.30 log units) between middle value and limit.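

In this assay compound 4 gives only a limit, the same one as compound 3: the limit of > 80000 nM in this assay, at which 2 of the 4 values shown sit. The change gives an at least 1.5-fold higher number from compound 1 to compound 4 (0.19 log units; that floor lies within the scatter), so a second replacement of the 4-fluorophenyl at this position yields no resolved difference and no measured number. The step between the two limits cannot be read, which leaves 4-methoxy-3-(trifluoromethyl)phenyl and 3,4,5-trimethoxyphenyl unranked. From the compounds shown here alone, whether an amine or a carboxylic acid on a saturated chain carbon bound to an amide-type nitrogen would lower the number stays open. So do the real values behind both limits.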